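Working notes: from compound 1 to compound 4

The source may hold more compounds than are shown below. What is called first, only, known or untested is meant among the compounds shown, and "the series" means these compounds.

Values in a functional assay on MDA-MB-231 cells (Homo sapiens) for antiproliferative activity, read by MTT assay, with a stated time of 24 h (on this read-out higher numbers stand for weaker inhibition and lower numbers for stronger inhibition), so far:
- compound 1 `COc1ccc(-c2noc(-c3ccncc3)n2)cc1OC1CCCC1` gives 240000 nM
- compound 2 `COc1ccc(-c2noc(Cc3c[nH]c4ccccc34)n2)cc1OC1CCCC1` gives > 1000000 nM as a limit of the assay, not a number
- compound 3 `Fc1ccc(-c2nc(-c3ccccc3)no2)cc1` gives > 1000000 nM as a limit of the assay, not a number

Among the compounds with values here, compound 1 holds the only true number, and at (240000 nM) it cannot be ranked by any exact gap against the other two compounds. Both of those stop at the same limit (the limit of > 1000000 nM in this assay, at which 2 of the 3 values shown sit). Within the data shown here, no step between measured compounds is available, so the size of any structural change on this core is not yet known from the data.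

The next compound is compound 4 `COc1ccc(-c2noc(-c3ccc(O)cc3)n2)cc1OC1CCCC1` with 4-hydroxyphenyl in place of pyridin-4-yl on an aromatic carbon of the five-membered aromatic ring with 2 nitrogen and 1 oxygen (4-hydroxyphenyl in place of pyridin-4-yl on an aromatic carbon). The rest of the structure is unchanged.

The estimated step of a 1.3-fold higher number from compound 1 to compound 4 (0.10 log units; within the scatter) is expected to stay within the usual scatter in this assay with a slight lean towards weaker inhibition. This expectation rests on compound 1 alone (240000 nM) and is therefore wide. Compound 4 is estimated at 300000 nM (expected range 90000 nM to 1000000 nM).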

Compound 4, half-maximal inhibitory concentration: 310 nM
Beside the measured number, compound 4's estimate is 970-fold (2.99 log units) above it; the measured number lies below the stated range.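

In this assay, within the data shown here, the first readable step on the shared core is a 770-fold lower number from compound 1 to compound 4 (2.89 log units; beyond the scatter), so a single change on the aromatic carbon next to the ring nitrogen and next to the ring oxygen can move the read-out far beyond the scatter, which no earlier value could show. In this step, 4-hydroxyphenyl brings in a hydrogen-bond donor and an all-carbon aromatic ring while the ring nitrogen of pyridin-4-yl leaves, and these differences travel together, so the step cannot be credited to either one alone. Nothing shown gives a cause for the size of this step.

As far as these compounds go, it remains open whether the hydroxyl group or the loss of the ring nitrogen carries the step, a question that plain phenyl, 4-methoxyphenyl or 4-aminophenyl on the same carbon would address. From the compounds shown here alone, it is also open how much the rest of the core of compound 4 contributes, for example whether an ethoxy group or a longer alkoxy chain in place of the cyclopentyloxy group keeps the value of compound 4.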